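A longer chain on compound 2

A few compounds are considered here, and "the series" means these few. Any claim that something is new, unique, unknown or untested is made for them only; others in the source may bear on it.

In a functional assay on A-375 cells (Homo sapiens) for cytotoxicity, read by MTT assay, with a stated time of 72 h (a lower number here means a stronger inhibitor, a higher number a weaker inhibitor), compound 1 `O=C1c2c[n+]([O-])c3ccccc3c2C(=O)c2c1c1ccccc1n2CCCCN1CCNCC1` gives 460 nM and compound 2 `CN1CCN(CCCn2c3c(c4ccccc42)C(=O)c2c[n+]([O-])c4ccccc4c2C3=O)CC1` gives 470 nM. Going by the values given here, these two values lie within the scatter of each other, so compound 2 stands level with the only other measured compound. Compound 3 `CN1CCN(CCCCCCn2c3c(c4ccccc42)C(=O)c2c[n+]([O-])c4ccccc4c2C3=O)CC1` keeps the shared core and differs from compound 2 at one place, on a saturated chain carbon, three bonds along the chain from an aromatic nitrogen: 3-(4-methylpiperazin-1-yl)propyl in place of 4-methylpiperazin-1-yl on a saturated chain carbon, three bonds along the chain from an aromatic nitrogen. Among the compounds with values here, one measured step bears on this change, a 1.0-fold higher number from compound 1 to compound 2 (0.01 log units; within the scatter), which put 4-methylpiperazin-1-yl in place of (piperazin-1-yl)methyl at that same place and stayed within the scatter. Within the data shown here, no measured step covers an addition this long, so the basis is thin. The expected change in this assay is small, with no clear direction, and the estimate is a 1.2-fold lower number from compound 2 to compound 3 (0.07 log units; within the scatter). Compound 3 is expected at 400 nM, with an estimated range of 150 nM to 1100 nM.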

Compound 3, half-maximal inhibitory concentration: 630 nM
Compound 3: the middle estimate sits 1.6-fold (0.20 log units) below what was measured, within the range that was stated.
By their numbers in this assay, from the lowest: compounds 1, 2 and 3 (each within the scatter of the next).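

In this assay, lengthening the chain gives a 1.3-fold higher number from compound 2 to compound 3 (0.13 log units; within the scatter), so 3-(4-methylpiperazin-1-yl)propyl in place of 4-methylpiperazin-1-yl, on a saturated chain carbon, three bonds along the chain from an aromatic nitrogen, stays within the scatter. Read from the other measured compound, the change gives a 1.4-fold higher number from compound 1 to compound 3 (0.14 log units; within the scatter), which is also within the scatter, so this position has now taken an addition of this length, not only the smaller swap seen before, without a change that can be told from scatter. No supporting measurement accompanies this result to account for it.

The compounds shown leave open whether a still longer chain would give the same result. They also leave open whether a morpholine or a carboxylic acid at the chain end, in place of the 4-methylpiperazin-1-yl group, would do so.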